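The compounds below may be only part of what the source reports. "The series", "measured", "known", "first", "only" and "open" are said of these compounds alone.

The study concerns two measured nucleoside analogues and one that still awaits measurement. Compound 1 `CC/N=C(\S)OC[C@H]1OC(n2cnc3c(NC4CCOC4)nc(Cl)nc32)[C@H](O)[C@@H]1O` gives 55 nM in an assay on DDT1 cells (Cricetulus griseus) for binding affinity to adenosine receptor A1 (Homo sapiens), read by radioligand binding; on this read-out higher numbers stand for weaker inhibition and lower numbers for stronger inhibition. Compound 2 `O=C(NC1CC1)OC[C@H]1OC(n2cnc3c(NC4CCOC4)ncnc32)[C@H](O)[C@@H]1O` gives 209 nM in this assay, the highest of the two numbers recorded; compound 1 sits a good way lower on the same scale, but the two structures differ in more than one place, so no single step can be read from that pair. Compound 3 `C=CCNC(=O)OC[C@H]1OC(n2cnc3c(NC4CCOC4)ncnc32)[C@H](O)[C@@H]1O` has not yet been measured. It differs from compound 2 in one place only: allyl in place of cyclopropyl on an amide-type nitrogen. Within the data shown here, no measured pair in the study shows how such an exchange moves the number, so the expectation rests on the modest size of the change alone, two groups of equal atom count rearranged on the same amide-type nitrogen. The step of a 1.1-fold lower number from compound 2 to compound 3 (0.04 log units; within the scatter) is therefore expected to stay within the usual scatter, with no clear direction. Compound 3 is accordingly expected to give about 190 nM in this assay, within a range from 80 nM to 450 nM.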

Compound 3, inhibition constant: 524 nM
Estimate against measurement, compound 3: 2.8-fold (0.44 log units) below, outside the stated range (above it).
By their numbers in this assay, from the lowest: compound 1; then compound 2; then compound 3.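

Among these compounds, the exchange of cyclopropyl for allyl on the amide-type nitrogen gives a 2.5-fold higher number from compound 2 to compound 3 (0.40 log units; beyond the scatter) in this assay, which is the first single-place change that can be read, since compound 1 and compound 2 differ in more than one place. Compound 2 and compound 3 contain the same atoms, joined differently, and both groups hold three carbons, so the read-out at this position responds to how those carbons are arranged and not only to how many there are. Here the closed three-membered ring goes with the stronger inhibition, and the open allyl group with its double bond goes with the weaker, but nothing shown accounts for this difference.

The compounds shown leave open whether the step follows from the loss of the ring or from the presence of the double bond, a question that a saturated propyl chain on the same nitrogen could help to separate. They also leave open how a larger group, such as cyclobutyl or a longer chain, would fare there, and whether the same exchange would move the number similarly on the core of compound 1.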